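Notes on the phenylsulfanyl chloro of compound 3

The source may report more compounds than this note shows. Statements on the series, on what has been measured and on what is new or still open speak of the compounds shown alone.

Among the compounds with values here, in a functional assay on DU-145 cells (Homo sapiens) for cytotoxicity, read by MTT assay (a lower number here means a stronger inhibitor, a higher number a weaker inhibitor), compound 3 `CC(O)(CSc1ccc(Cl)cc1)c1nc(-c2ccc(Cl)cc2)no1` gives 14500 nM, the highest of the two numbers so far; the nearest is compound 2 `CC(O)(CSc1ccccc1)c1nc(-c2ccc(F)c(Cl)c2)no1`, which gives 5500 nM. Compound 1 `CC(O)(CSc1ccccc1)c1nc(-c2ccccc2)no1` gives > 100000 nM, which is a limit of this assay and not a number (the limit of > 100000 nM in this assay, at which 1 of the 3 values shown sits). Compound 2 and compound 3 differ in two places, so their values are only set side by side.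

Compound 4 `CC(O)(CSc1ccccc1)c1nc(-c2ccc(Cl)cc2)no1` differs from compound 3 by hydrogen in place of chloro on an aromatic carbon. Within the data shown here, the one measured step, an at least 18-fold lower number from compound 1 to compound 2 (1.25 log units; beyond the scatter), concerns the other aromatic ring, the one attached to the shared core, and does not touch the phenylsulfanyl ring; no measured step bears on the change from compound 3 to compound 4 directly. Among the measured compounds shown here, the only compound with an unsubstituted phenylsulfanyl group is compound 1, whose value is a limit, so the direction of the step is open. In this assay the number for compound 4 is expected to move by a 2.1-fold higher number from compound 3 to compound 4 (0.32 log units; beyond the scatter), towards a higher number, with a real chance of none beyond the scatter or of a limit. Compound 4 is estimated at 30000 nM, between 8000 nM and 100000 nM.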

Compound 4, half-maximal inhibitory concentration: 4500 nM
Compound 4: middle estimate off by 6.7-fold (0.82 log units), on the high side, and the stated range ends above it.
By their numbers in this assay, from the lowest: compounds 4 and 2 (each within the scatter of the next); then compound 3. At a limit, above all of these: compound 1.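

In this assay, within the data shown here, the change from (4-chlorophenyl)sulfanyl to phenylsulfanyl gives the first direct reading on this ring, a 3.2-fold lower number from compound 3 to compound 4 (0.51 log units; beyond the scatter), so with the 4-chlorophenyl group held constant, chloro on this ring goes with the weaker compound. With phenylsulfanyl held constant, 4-chlorophenyl in place of 3-chloro-4-fluorophenyl gives a 1.2-fold lower number from compound 2 to compound 4 (0.09 log units; within the scatter), so the two substituted rings attached to the shared core cannot be told apart in this assay. Chloro in place of hydrogen on that other ring gives an at least 22-fold lower number from compound 1 to compound 4 (1.34 log units; beyond the scatter), which shows that a single chloro there is enough for a large step, but compound 1 stands at a limit, so the size of this step is only a bound: the limit of > 100000 nM in this assay, at which 1 of the 4 values shown sits.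

Open, going by these compounds, is whether a methoxy group or an amine in place of chloro on the phenylsulfanyl ring would move the number in the same direction as chloro. Also open, on these data alone, is whether the step from (4-chlorophenyl)sulfanyl to phenylsulfanyl keeps its direction and size with 3-chloro-4-fluorophenyl in place of 4-chlorophenyl.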